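Aryloxy replacement on the ring oxygen of compound 3

The source may report more compounds than this note shows. Statements on the series, on what has been measured and on what is new or still open speak of the compounds shown alone.

The three measured compounds share a core and vary only in the chain on the ring-bound oxygen. Compound 1 `CCCCCON1C(=O)[C@@H](NC(=O)OCCCCC2CCCCC2)[C@@H]1C` gives 387 nM in an assay on HEK293 cells for inhibition of N-acylethanolamine-hydrolyzing acid amidase (Homo sapiens), read by fluorescence, with stated times of 10 min and 50 min; on this read-out lower numbers stand for stronger inhibition and higher numbers for weaker inhibition. Compound 2 `CSCCCON1C(=O)[C@@H](NC(=O)OCCCCC2CCCCC2)[C@@H]1C` gives 167 nM, and compound 3 `CC(=O)CCCON1C(=O)[C@@H](NC(=O)OCCCCC2CCCCC2)[C@@H]1C` gives 75 nM, the lowest of the three numbers. The steps were a 2.3-fold lower number from compound 1 to compound 2 (0.36 log units; beyond the scatter), a 5.2-fold lower number from compound 1 to compound 3 (0.71 log units; beyond the scatter) and a 2.2-fold lower number from compound 2 to compound 3 (0.35 log units; beyond the scatter), each modest and each concerning the end of the chain only.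

Compound 4 `C[C@H]1[C@H](NC(=O)OCCCCC2CCCCC2)C(=O)N1Oc1ccc(C(F)(F)F)cc1` differs from compound 3 by 4-(trifluoromethyl)phenyl in place of 3-acetylpropyl on an oxygen. Among the compounds with values here, none of the measured steps exchanges the chain for a ring, so they bear on this change only indirectly: they show that the group on this oxygen shifts the number modestly, with no example of an aryl group. The expectation is therefore uncertain and wide, leaning toward a higher number: the step is estimated as a 4.0-fold higher number from compound 3 to compound 4 (0.60 log units; beyond the scatter). Compound 4 is expected at 300 nM, within 80 nM to 1500 nM.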

Compound 4, half-maximal inhibitory concentration: 31 nM
Estimate against measurement, compound 4: 9.7-fold (0.99 log units) above; the whole stated range lies above it.
By their numbers in this assay, from the lowest: compound 4; then compound 3; then compound 2; then compound 1.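

Compound 4 carries the only aromatic ring on this oxygen among the compounds shown, and in this assay the 4-(trifluoromethyl)phenyl group costs nothing: exchanging it for 3-acetylpropyl gives a 2.4-fold lower number from compound 3 to compound 4 (0.38 log units; beyond the scatter) and places compound 4 lowest of the four. Against the other chains the same group gives a 5.4-fold lower number from compound 2 to compound 4 (0.73 log units; beyond the scatter) and a 12-fold lower number from compound 1 to compound 4 (1.10 log units; beyond the scatter) and the latter is the only large step in the set. The position therefore accepts a ring as well as a chain, and the group on this oxygen can move the number further than the changes at the chain ends had shown.

From the compounds shown here alone, whether the lower number comes from the ring or from the trifluoromethyl group stays open, and a plain phenyl, a methoxyphenyl or a pyridine ring on this oxygen would separate the two. Nothing at hand explains the gain.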